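The source may report more compounds than this note shows. Statements on the series, on what has been measured and on what is new or still open speak of the compounds shown alone.

Measured compounds:
- Compound 1 `Cc1ccc(C)c(-n2nncc2CN2C(=O)C3(C(C#N)=C(N)Oc4c3c3nc5ccccc5nc3c3ccccc43)c3ccccc32)c1`: > 50000 nM in a functional assay on A549 cells (Homo sapiens) for antiproliferative activity, read by MTT assay, with a stated time of 48 h; on this read-out higher numbers stand for weaker inhibition and lower numbers for stronger inhibition
- Compound 2 `N#CC1=C(N)Oc2c(N)cc3nc4ccccc4nc3c2C12C(=O)N(Cc1cnnn1-c1ccccc1Cl)c1ccccc12`: 29800 nM in this assay

For compound 1 the value in this assay is a limit of the assay, not a number (the limit of > 50000 nM in this assay, at which 1 of the 2 values shown sits). Going by the values given here, compound 2 therefore gives the only actual number in this assay, and it marks weak inhibition.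

Compound 3 `CCOc1ccccc1-n1nncc1CN1C(=O)C2(C(C#N)=C(N)Oc3c(N)cc4nc5ccccc5nc4c32)c2ccccc21` differs from compound 2 in one place: ethoxy in place of chloro on an aromatic carbon. Among the compounds with values here, no measured pair shows the effect of such a change here, so the step from compound 2 to compound 3 in this assay is expected to stay within the usual scatter, a 1.2-fold higher number from compound 2 to compound 3 (0.07 log units; within the scatter). Compound 3 is therefore estimated at 35000 nM, with a range from 12000 nM to 100000 nM.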

Compound 3, half-maximal inhibitory concentration: > 50000 nM
Compound 3: a limit, no number; the forecaster's own chance of this, stated with the estimate: 35%; at least 1.4-fold (0.15 log units) between middle value and limit.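

Compound 3 sits at a limit of the assay, not at a number: the limit of > 50000 nM in this assay, at which 2 of the 3 values shown sit. Going by these compounds alone, this gives the first measured step at this position, and the change from 2-chlorophenyl to 2-ethoxyphenyl in this assay reads as an at least 1.6-fold higher number from compound 2 to compound 3 (0.22 log units; that floor lies within the scatter). Ethoxy therefore brought no stronger inhibition than chloro here, but the floor of the step is too small to establish a real loss.

Going by these compounds, the true size of the step stays open. So does what a methoxy or an amine on this same aromatic carbon would give in this assay.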